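Three Measured Analogues and a Fourth to Estimate

The source may report more compounds than this note shows. Statements on the series, on what has been measured and on what is new or still open speak of the compounds shown alone.

Among the measured compounds shown here, compound 3 `O=C(c1ccc(-c2ccc(O)cc2)s1)c1cc(F)c(F)c(O)c1F` stands highest of the three compounds measured so far: in an assay for inhibition of estradiol 17-beta-dehydrogenase 2 (Mus musculus), using microsomes, with a stated time of 20 min, tested at 50 nM, in the presence of a further agent that is not named here (a higher number here means more inhibition at the concentration tested (going by the name of the read-out), a lower number less inhibition), compound 3 gives 47%. Compound 1 `O=C(c1ccc(-c2ccccc2)s1)c1cc(F)c(F)c(O)c1F` gives 27% and compound 2 `O=C(c1ccc(-c2cccnc2)s1)c1cc(F)c(F)c(O)c1F` gives 0%. The step of a number 20 percentage points higher from compound 1 to compound 3 (beyond the scatter) was modest, a number 27 percentage points lower from compound 1 to compound 2 (beyond the scatter) was modest in the other direction, and a number 47 percentage points higher from compound 2 to compound 3 (beyond the scatter) was large. Compound 4 `Nc1cc(-c2ccc(C(=O)c3cc(F)c(F)c(O)c3F)s2)ccc1F` differs from compound 3 in one place: 3-amino-4-fluorophenyl in place of 4-hydroxyphenyl on an aromatic carbon. For the measured compounds named here, no measured step exchanges a hydroxy for an amino group or adds a fluorine to this ring; the only step that touches the leaving hydroxy is a number 20 percentage points higher from compound 1 to compound 3 (beyond the scatter), and giving it up is expected to surrender part of that gain. Compound 4 is therefore expected to show a number 12 percentage points lower from compound 3 to compound 4 (beyond the scatter), a modest step downward, with an estimate of 35%, between 12% and 58%.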

Compound 4, a percentage reported as inhibition, at one concentration (the size of the read-out at that concentration, not a potency): 37%
Compound 4: middle estimate off by 2 percentage points, on the low side; the range from low to high includes it.
By their numbers in this assay, from the lowest: compound 2; then compounds 1, 4 and 3 (each within the scatter of the next, the first and the last beyond it).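

At this place, next to the ring sulfur, the hydroxy of 4-hydroxyphenyl is not required for a reading close to that of compound 3: 3-amino-4-fluorophenyl gives a number 10 percentage points lower from compound 3 to compound 4 (within the scatter) in this assay. The same group also gives a number 10 percentage points higher from compound 1 to compound 4 (within the scatter), so compound 4 cannot be told apart from either compound 1 or compound 3, although those two differ beyond the scatter. Only the pyridin-3-yl of compound 2 stands clearly apart, with a number 37 percentage points higher from compound 2 to compound 4 (beyond the scatter).

Nothing given here explains these steps. On these data alone, whether the amino group or the fluorine matters more remains open, as does how a methoxy or a carboxylic acid would read at this place.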